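The compounds below may be only part of what the source reports. "The series", "measured", "known", "first", "only" and "open" are said of these compounds alone.

Working notes on the chalcone series carrying the guanylhydrazone arm. Compound 1 `N=C(N)N/N=C/c1ccc(/C=C/C(=O)c2cccc(Br)c2)cc1` gives 49.7% in a functional assay on the whole organism (Ear) for inhibition, with Mus musculus as the target, with a stated time of 30 min, at a dose of 100 mg/kg by the intraperitoneal route; on this read-out lower numbers stand for less inhibition and higher numbers for more inhibition at the one dose given (going by the name of the read-out). Compound 2 `Cc1ccc(C(=O)/C=C/c2ccc(/C=N/NC(=N)N)cc2)cc1` gives 77.7%, and compound 3 `COc1ccc(C(=O)/C=C/c2ccc(/C=N/NC(=N)N)cc2)cc1` gives 57.2%. Among these three numbers compound 3 sits apart from compound 2 only, the step being a number 20.5 percentage points lower from compound 2 to compound 3 (beyond the scatter); against compound 1 the step of a number 7.5 percentage points higher from compound 1 to compound 3 (within the scatter) does not separate the two. Swapping the aryl on the carbonyl carbon therefore moved the read-out in one of the two cases, a number 28 percentage points higher from compound 1 to compound 2 (beyond the scatter), and not in the other.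

Compound 4 `N=C(N)N/N=C/c1ccc(/C=C/C(=O)c2ccccc2F)cc1` is the next member: 2-fluorophenyl in place of 4-methoxyphenyl on a carbonyl carbon. For the measured compounds named here, the steps that bear on it are a number 7.5 percentage points higher from compound 1 to compound 3 (within the scatter) and a number 20.5 percentage points lower from compound 2 to compound 3 (beyond the scatter), which show that an aryl change at this carbonyl carbon can shift the read-out modestly or leave it within the scatter. Going by the values given here, compound 1 is the only measured compound carrying a halogen on that ring, at 49.7%, and nothing measured speaks for 2-fluorophenyl in particular. The step of a number 7.2 percentage points lower from compound 3 to compound 4 (within the scatter) is expected to be small, downward if anything, and not clearly beyond the scatter. The read-out of compound 4 is therefore estimated at 50%, with a range from 30% to 70%.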

Compound 4, a percentage reported as inhibition, in the whole organism at one dose (the size of the read-out at that dose, not a potency): 91.7%
The estimate for compound 4 lay 41.7 percentage points below the measured number; measured number above the stated range.
By their numbers in this assay, from the lowest: compounds 1 and 3 (each within the scatter of the next); then compound 2; then compound 4.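

At the aryl on the carbonyl carbon, 2-fluorophenyl gives the highest number in the series in this assay: the change gives a number 34.5 percentage points higher from compound 3 to compound 4 (beyond the scatter) and a number 14 percentage points higher from compound 2 to compound 4 (beyond the scatter) and also a number 42 percentage points higher from compound 1 to compound 4 (beyond the scatter), so compound 4 stands clear of all three earlier compounds, and this position can carry a far larger shift than the earlier aryl swaps suggested. The two halogen-bearing compounds, compound 1 and compound 4, lie at the two ends of the series, which shows that a halogen on this ring does not by itself set the level of the read-out. No measurement at hand accounts for the rise, and the size of the step remains an observation without an explanation.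

The shown compounds do not separate the element from its place on the ring, as 3-bromophenyl and 2-fluorophenyl differ in both, and 4-fluorophenyl and 2-chlorophenyl are the groups that would tell these apart. On these data alone, how an amine or a carboxylic acid on this ring would read, and how compound 4 behaves at other doses, also stays open.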